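From dimethylamino to pyrrolidin-1-yl on a hydroxy compound

This account rests on a few compounds, and the source may have more. Where it says the series, first, only, none or still open, it means among the compounds named here.

In an ADME assay on L6 cells (Rattus norvegicus) for cytotoxicity (a higher number here means a weaker inhibitor, a lower number a stronger inhibitor), compound 1 `O=C1CC2(N3CCCC3)CC(c3ccccc3)C1C(c1ccccc1)C2` gives 26500 nM and compound 2 `O=C1CC2(N3CCCCC3)CC(c3ccccc3)C1C(c1ccccc1)C2` gives 46900 nM. Compound 3 `CN(C)C12CC(O)C(C(c3ccccc3)C1)C(c1ccccc1)C2` gives 133000 nM, the highest of the three numbers, and its gap to each of the other two lies beyond the scatter.

Compound 4 `OC1CC2(N3CCCC3)CC(c3ccccc3)C1C(c1ccccc1)C2` has not yet been measured. It keeps the hydroxy group of compound 3 and differs from it in one place: pyrrolidin-1-yl in place of dimethylamino on a saturated ring carbon. In words, this is pyrrolidin-1-yl in place of dimethylamino on a saturated ring carbon.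

The closest measured exchange of one amino group for another is piperidin-1-yl in place of pyrrolidin-1-yl on a saturated ring carbon, which gave a 1.8-fold higher number from compound 1 to compound 2 (0.25 log units; within the scatter). That step stayed within the scatter, though it involves a different pair of groups. Within the data shown here, compound 1, at 26500 nM, also carries pyrrolidin-1-yl, but it has a carbonyl where compound 3 has the hydroxy group, and no measured pair separates that difference. In this assay, a step no larger than the scatter is therefore expected, leaning slightly towards a lower number. The expected step is a 1.4-fold lower number from compound 3 to compound 4 (0.15 log units; within the scatter). Compound 4 is estimated at 95000 nM, with an expected range of 40000 nM to 200000 nM.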

Compound 4, half-maximal inhibitory concentration: 26800 nM
The estimate for compound 4 lay 3.5-fold (0.55 log units) above the measured number, and the stated range ends above it.
By their numbers in this assay, from the lowest: compounds 1, 4 and 2 (each within the scatter of the next); then compound 3.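

Among these compounds, with the hydroxy group kept, the exchange of dimethylamino for pyrrolidin-1-yl on this saturated ring carbon gives a 5.0-fold lower number from compound 3 to compound 4 (0.70 log units; beyond the scatter) in this assay, so the amino group at this position can move the number beyond the scatter, unlike the only earlier exchange of one amino group for another, which gave a 1.8-fold higher number from compound 1 to compound 2 (0.25 log units; within the scatter) on the carbonyl compounds. The result also supplies the first pair that separates hydroxy from carbonyl with pyrrolidin-1-yl held constant: compound 1 gives 26500 nM and compound 4 gives 26800 nM, values within the scatter of each other, so among the compounds shown, only compound 3 stands apart. No measurement available here accounts for the size of the step from dimethylamino to pyrrolidin-1-yl.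

The compounds shown leave open whether piperidin-1-yl on the hydroxy compound would stay within the scatter of compound 4, and whether dimethylamino on the carbonyl compound would give a number as high as that of compound 3. They also leave open how a morpholin-4-yl group or a primary amine at this position would read in this assay.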